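The compounds below may be only part of what the source reports. "The series", "measured", "known", "first", "only" and "open" are said of these compounds alone.

Measured in a functional assay on CAL-51 cells (Homo sapiens) for inhibition, read by sulforhodamine B assay, with a stated time of 3 days; a higher number here means a weaker inhibitor of growth, a lower number a stronger inhibitor of growth:

- compound 1 `Cc1ccc(COc2ccc(C(=O)/C=C/c3ccccc3)cc2)cc1`: 43200 nM
- compound 2 `O=C(/C=C/c1ccccc1)c1ccc(OCc2ccccc2)cc1`: 28900 nM
- compound 3 `Cc1ccc(COc2ccc(C(=O)/C=C/c3ccc(F)cc3)cc2)cc1`: > 50000 nM (a limit of the assay, not a number)

Only two of these compounds have true numbers, and they lie within the scatter of each other, as the step of a 1.5-fold lower number from compound 1 to compound 2 (0.17 log units; within the scatter) shows. Compound 1 therefore stands level with compound 2 at 28900 nM. Compound 3 reports only a limit, > 50000 nM.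

Compound 4 `O=C(/C=C/c1ccc(Cl)cc1)c1ccc(OCc2ccccc2)cc1` has not yet been measured. It differs from compound 2 by one change: chloro in place of hydrogen on an aromatic carbon. This is chloro in place of hydrogen on an aromatic carbon, turning phenyl into 4-chlorophenyl.

Among the compounds with values here, no chloro step has been measured. The nearest evidence is the fluoro step an at least 1.1-fold higher number from compound 1 to compound 3 (0.06 log units; that floor lies within the scatter), which gives only a floor, and that floor lies within the scatter. The methyl step from compound 1 to compound 2 is a change of another kind and stays within the scatter too. The expectation is therefore no clear shift beyond the scatter, with any drift more likely towards a higher number, as the limit reached by compound 3 at > 50000 nM hints. The expected step is a 1.1-fold higher number from compound 2 to compound 4 (0.04 log units; within the scatter). Compound 4 is estimated at 32000 nM, with an expected range from 13000 nM to 60000 nM.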

Compound 4, concentration for 50% growth inhibition: > 50000 nM
Compound 4 gave a limit, no number; the forecaster's own chance of this, stated with the estimate: 25%; middle value at least 1.5-fold (0.19 log units) from the limit.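

In this assay, within the data shown here, the change from phenyl to 4-chlorophenyl gives the first chloro step, an at least 1.7-fold higher number from compound 2 to compound 4 (0.23 log units; that floor lies within the scatter), and it starts from the parent without the methyl group, whereas the fluoro step started from the methylated compound 1. Compound 4 gives only a limit of the assay, not a number, so its step sets a floor and cannot say how large the change really is. Even so, a halogen on this aromatic carbon, para to a large group, now ends at that limit on both backgrounds, in compound 3 and compound 4, while compound 1 and compound 2, which keep the plain phenyl, give true numbers: the limit of > 50000 nM in this assay, at which 2 of the 4 values shown sit.

From the compounds shown here alone, neither halogen step goes beyond the scatter on its floor, so whether these substitutions truly weaken growth inhibition, and by how much, remains open. The compounds shown also leave open how a methoxy group, an amine or a carboxylic acid at this position would read, so the trend rests on two halogens alone.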